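The source may hold more compounds than are shown below. What is called first, only, known or untested is meant among the compounds shown, and "the series" means these compounds.

Among the compounds with values here, in an assay on Sf9 cells for inhibition of histone deacetylase 11 (Homo sapiens), read by fluorescence, tested at 0.5 uM (on this read-out lower numbers stand for less inhibition and higher numbers for more inhibition at the one concentration tested (going by the name of the read-out)), compound 3 `O=C(/C=C/c1cn([C@@H]2C[C@H](C(=O)O)N(CCCc3ccccc3)C2)nn1)NO` gives 11%, one of only two plain numbers reported, and the other belongs to compound 2 `O=C(NO)c1ccc(-c2cn([C@H]3C[C@@H](C(=O)O)N(CCCc4ccccc4)C3)nn2)cc1`, which in this assay gives 14%, a gap that lies within the scatter. Compound 1 `O=C(/C=C/c1cn([C@@H]2C[C@@H](C(=O)O)N(CCCc3ccccc3)C2)nn1)NO` returns in this assay only a limit, < 10%. Compound 4 `O=C(/C=C/c1cn([C@H]2C[C@@H](C(=O)O)N(CCCc3ccccc3)C2)nn1)NO` has not yet been measured; it differs from compound 3 as follows: the two compounds have the same atoms and bonds and differ only in configuration as drawn: 2 of 3 stereo elements differ; a stereocentre at a saturated ring carbon is drawn R in compound 3 and S in compound 4; a stereocentre at a saturated ring carbon is drawn R in compound 3 and S in compound 4. Within the data shown here, the one measured step that concerns configuration alone, a number at least 1 percentage points higher from compound 1 to compound 3 (that floor lies within the scatter), was small and rests on the fact that compounds 1 and 3 differ only in the configuration as drawn and (the limit of < 10% in this assay, at which 1 of the 3 values shown sits). No movement beyond the scatter is therefore expected from compound 3 to compound 4 in this assay; the estimated step is no change at the digits printed from compound 3 to compound 4 (within the scatter). Compound 4 is expected to give 11%, with a range from 4% to 20%.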

Compound 4, a percentage reported as inhibition, at one concentration (the size of the read-out at that concentration, not a potency): 29%
The estimate for compound 4 lay 18 percentage points below the measured number; the whole stated range lies below it.
By their numbers in this assay, from the lowest: compounds 3 and 2 (each within the scatter of the next); then compound 4. At a limit, below all of these: compound 1.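

In this assay, configuration alone now moves the number beyond the scatter, with a number 18 percentage points higher from compound 3 to compound 4 (beyond the scatter) and, for a single stereocentre, a number at least 19 percentage points higher from compound 1 to compound 4 (beyond the scatter). That second step starts from compound 1, whose < 10% is a limit. The group on the aromatic carbon also matters in this configuration: 2-(hydroxycarbamoyl)ethenyl in place of 4-(hydroxycarbamoyl)phenyl gives a number 15 percentage points higher from compound 2 to compound 4 (beyond the scatter). The compounds shown leave open how the number would respond to a methyl ester in place of the carboxylic acid, or to a longer chain ending in phenyl.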